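Compound 4: 4-chlorobutyl in place of but-1-en-1-yl

The source may report more compounds than this note shows. Statements on the series, on what has been measured and on what is new or still open speak of the compounds shown alone.

- Compound 1 `COc1ccc(CN(C(C)=O)c2cc(OC)c(OC)c(OC)c2)cc1O`: 79 nM
- Compound 2 `COc1ccc(CN(C(=O)C=C(C)C)c2cc(OC)c(OC)c(OC)c2)cc1O`: 320 nM
- Compound 3 `CC/C=C/C(=O)N(Cc1ccc(OC)c(O)c1)c1cc(OC)c(OC)c(OC)c1`: 58 nM

These values come from a functional assay on MGC-803 cells (Homo sapiens) for inhibition, read by MTT assay, with a stated time of 48 h; on this read-out higher numbers stand for weaker inhibition and lower numbers for stronger inhibition. Compound 3 has the lowest of the three numbers, but only compound 2 stands clearly apart from it, with a 5.5-fold lower number from compound 2 to compound 3 (0.74 log units; beyond the scatter). Compound 1 stays within the scatter of it, with a 1.4-fold lower number from compound 1 to compound 3 (0.13 log units; within the scatter).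

Compound 4 `COc1ccc(CN(C(=O)CCCCCl)c2cc(OC)c(OC)c(OC)c2)cc1O` keeps the shared core and differs from compound 3 only on the carbonyl carbon: 4-chlorobutyl in place of but-1-en-1-yl on a carbonyl carbon. Going by the values given here, no measured step makes this exchange, and no measured compound carries 4-chlorobutyl. The closest evidence is the other changes at this carbon. Compound 2 shows that such a change can matter, with a 4.1-fold higher number from compound 1 to compound 2 (0.61 log units; beyond the scatter), while compound 3 shows that it need not. With compound 3 already at the low end of the numbers in this assay, a modest move to a higher number is expected. The estimated change is a 2.2-fold higher number from compound 3 to compound 4 (0.35 log units; beyond the scatter). For compound 4 the estimated value is 130 nM, with an expected range of 40 nM to 420 nM.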

Compound 4, half-maximal inhibitory concentration: 540 nM
Compound 4: the middle estimate sits 4.2-fold (0.62 log units) below what was measured, outside the stated range (above it).
By their numbers in this assay, from the lowest: compounds 3 and 1 (each within the scatter of the next); then compounds 2 and 4 (each within the scatter of the next).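

In this assay, going by these compounds alone, the exchange of but-1-en-1-yl for 4-chlorobutyl on the carbonyl carbon gives a 9.3-fold higher number from compound 3 to compound 4 (0.97 log units; beyond the scatter), the widest step seen at this place so far, and it shows that a chain with no double bond can lose much of what compound 3 holds. The new chain also stands clear of the methyl group, with a 6.8-fold higher number from compound 1 to compound 4 (0.83 log units; beyond the scatter), while a 1.7-fold higher number from compound 2 to compound 4 (0.23 log units; within the scatter) leaves it level with 2-methylprop-1-en-1-yl, so two quite different groups here give similar numbers. Nothing available explains why these groups separate as they do.

The compounds shown leave open whether the change follows the chlorine or the loss of the double bond. A plain butyl chain would bear on that, and an amine in place of the chlorine would test the chain end.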